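Working notes: the step from compound 3 to compound 4

The source may hold more compounds than are shown below. What is called first, only, known or untested is meant among the compounds shown, and "the series" means these compounds.

compound 1, `Cc1ccc2nc(C(=O)Nc3c(F)cc(-c4cccc(F)c4)cc3F)c(C)c(O)c2c1`: 0.98%
compound 2, `Cc1c(C(=O)Nc2c(F)cc(-c3cccc(F)c3)cc2F)nc2ccc(C(F)(F)F)cc2c1O`: 0.06%
compound 3, `Cc1ccc2nc(C(=O)Nc3c(F)cc(-c4cccc(F)c4)cc3F)c(C)c(C(=O)O)c2c1`: 1.05%

All three numbers come from a functional assay on Hep 3B2 cells (Homo sapiens) for antiproliferative activity, read by MTT assay, with a stated time of 24 h, tested at 0.02 ug/mL; a lower number here means a weaker effect, a higher number a stronger effect of the compound at the concentration tested. Compound 3 holds the highest of the three numbers, yet every gap is within the scatter: a number 0.1 percentage points higher from compound 1 to compound 3 (within the scatter) and a number 0.9 percentage points lower from compound 1 to compound 2 (within the scatter), so nothing has moved beyond noise so far.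

Compound 4 is `COc1ccc2nc(C(=O)Nc3c(F)cc(-c4cccc(F)c4)cc3F)c(C)c(C(=O)O)c2c1`. It differs from compound 3 in one place: methoxy in place of methyl on an aromatic carbon. Within the data shown here, no measured step changes methyl to methoxy; the only step at this position, trifluoromethyl in place of methyl from compound 1 to compound 2, stayed within the scatter, and the carboxy step from compound 1 to compound 3 did likewise. A step of no size beyond the scatter is therefore expected, a number 0.1 percentage points lower from compound 3 to compound 4 (within the scatter). Compound 4 is estimated at 1%, in the range 0% to 4%.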

Compound 4, a percentage reported as inhibition, at one concentration (the size of the read-out at that concentration, not a potency): -0.57%
The estimate for compound 4 lay 1.6 percentage points above the measured number; measured number outside the range, below it.
By their numbers in this assay, from the lowest: compounds 4, 2, 1 and 3 (each within the scatter of the next).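

In this assay, methoxy in place of methyl on this aromatic carbon gives a number 1.6 percentage points lower from compound 3 to compound 4 (within the scatter) and so adds an oxygen-linked group to the trifluoromethyl change, which gave a number 0.9 percentage points lower from compound 1 to compound 2 (within the scatter) with hydroxy in place of carboxy elsewhere on the core. Both changes at this position stay within the scatter, one in each of the two backgrounds, so neither group separates from methyl here. No measurement on hand bears on why the read-out stays this flat.

On these data alone, whether an amine or a longer chain such as butoxy at this position would move the number beyond the scatter remains open. The same holds for a chlorine in this place on the hydroxy-bearing core of compound 1.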